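This account rests on a few compounds, and the source may have more. Where it says the series, first, only, none or still open, it means among the compounds named here.

Compound 3 `Cc1nn(C(=O)c2ccccc2)c(N)c1-c1ccc(Cl)c(Cl)c1` stands highest of the two numbers in an assay on Sf9 cells for inhibition of mitogen-activated protein kinase kinase kinase 14 (Homo sapiens), read by ADP-Glo, with a stated time of 60 min (a higher number here means a weaker inhibitor, a lower number a stronger inhibitor), where compound 3 gives 23000 nM. The nearest value comes from compound 1 `CC(=O)n1nc(C)c(-c2ccc(Cl)c(Cl)c2)c1N`, which gives 8400 nM. That step is a 2.7-fold higher number from compound 1 to compound 3 (0.44 log units; beyond the scatter). Compound 2 `CCCC(=O)n1nc(C)c(-c2ccc(Cl)c(Cl)c2)c1N` reaches only a limit in this assay, > 100000 nM. Relevant here: the limit of > 100000 nM in this assay, at which 1 of the 3 values shown sits. The other steps on the carbonyl carbon were an at least 11-fold higher number from compound 1 to compound 2 (1.07 log units; beyond the scatter) and an at least 4.3-fold lower number from compound 2 to compound 3 (0.63 log units; beyond the scatter). Compound 4 `Cc1nn(C(=O)c2ccncc2)c(N)c1-c1ccc(Cl)c(Cl)c1` differs by pyridin-4-yl in place of phenyl on a carbonyl carbon. Going by the values given here, no measured step exchanges one aromatic group for another on that carbon, so the change is expected to stay within the scatter, at most modest. The expected step is a 1.2-fold lower number from compound 3 to compound 4 (0.06 log units; within the scatter). Compound 4 is therefore estimated at 20000 nM, within 7000 nM to 60000 nM.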

Compound 4, half-maximal inhibitory concentration: 58200 nM
The estimate for compound 4 lay 2.9-fold (0.46 log units) below the measured number; the measured number falls inside the stated range.
By their numbers in this assay, from the lowest: compound 1; then compound 3; then compound 4. At a limit, above all of these: compound 2.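

In this assay the carbonyl carbon does not treat these two aromatic groups alike: pyridin-4-yl in place of phenyl gives a 2.5-fold higher number from compound 3 to compound 4 (0.40 log units; beyond the scatter). The two rings are of equal heavy-atom count. Against methyl, the same group gives a 6.9-fold higher number from compound 1 to compound 4 (0.84 log units; beyond the scatter) and so lies further from compound 1 than phenyl does, leaving neither aromatic group level with compound 1. Against propyl, the same group gives an at least 1.7-fold lower number from compound 2 to compound 4 (0.23 log units; that floor lies within the scatter). Compound 2 stands at a limit: the limit of > 100000 nM in this assay, at which 1 of the 4 values shown sits.

As far as these compounds go, whether the change follows the ring nitrogen as such stays open. Pyridin-3-yl, or an amine on the phenyl ring, could test this on the same carbonyl carbon.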